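A longer chain on compound 3

The compounds below may be only part of what the source reports. "The series", "measured", "known", "first", "only" and "open" are said of these compounds alone.

Among the measured compounds shown here, in a functional assay on A549 cells (Homo sapiens) for inhibition, read by sulforhodamine B assay, with a stated time of 72 h (on this read-out higher numbers stand for weaker inhibition and lower numbers for stronger inhibition), compound 3 `C#Cc1cccc(Nc2ncnc3cc(OCCCCn4ccnc4[N+](=O)[O-])c(OC)cc23)c1` gives 2210 nM, the lowest of the three numbers so far. Compound 1 `COc1cc2c(Nc3ccc(F)c(Cl)c3)ncnc2cc1OCCCCCCn1ccnc1[N+](=O)[O-]` gives 13400 nM and compound 2 `COc1cc2c(Nc3ccc(F)c(Cl)c3)ncnc2cc1OCCOCCn1ccnc1[N+](=O)[O-]` gives 12900 nM, both clearly higher. Compound 4 `C#Cc1cccc(Nc2ncnc3cc(OCCCCCn4ccnc4[N+](=O)[O-])c(OC)cc23)c1` differs from compound 3 only at the end of its chain: (2-nitro-1H-imidazol-1-yl)methyl in place of 2-nitro-1H-imidazol-1-yl on a saturated chain carbon, four bonds along the chain from an oxygen on an aromatic ring. Here (2-nitro-1H-imidazol-1-yl)methyl stands in place of 2-nitro-1H-imidazol-1-yl on a saturated chain carbon. For the measured compounds named here, the one measured step within a chain, a 1.0-fold lower number from compound 1 to compound 2 (0.02 log units; within the scatter), lies within the scatter. It is a different change from this one, so it is only a weak guide, and no shift beyond the scatter is expected. The expected size of the move is a 1.1-fold higher number from compound 3 to compound 4 (0.05 log units; within the scatter). For compound 4 the estimated value is 2500 nM, with an expected range from 1100 nM to 5500 nM.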

Compound 4, half-maximal inhibitory concentration: 770 nM
The estimate for compound 4 lay 3.2-fold (0.51 log units) above the measured number; measured number outside the range, below it.
By their numbers in this assay, from the lowest: compound 4; then compound 3; then compounds 2 and 1 (each within the scatter of the next).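

In this assay, one more saturated carbon in the chain carrying the 2-nitro-1H-imidazol-1-yl ring gives a 2.9-fold lower number from compound 3 to compound 4 (0.46 log units; beyond the scatter), so the length of this chain can change the read-out. The earlier step within a chain, a 1.0-fold lower number from compound 1 to compound 2 (0.02 log units; within the scatter), had shown no such shift, and this is the first change there to move the number beyond the scatter. Nothing measured here explains the gain. As far as these compounds go, whether a longer chain on compound 4 would lower the number further or raise it remains open. So does the effect of an amine in place of the nitro group on the ring.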